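Cytotoxicity of Amide Variants on a Shared Core

The compounds below may be only part of what the source reports. "The series", "measured", "known", "first", "only" and "open" are said of these compounds alone.

Compounds measured so far:
compound 1 `Cc1nc2cc(C(=O)NCc3ccc(F)cc3)nn2c(-c2cc(F)c3c(c2C)CCCO3)c1[C@H](OC(C)(C)C)C(=O)O` — > 40000 nM
compound 2 `CCc1cc(CNC(=O)c2cc3nc(C)c([C@H](OC(C)(C)C)C(=O)O)c(-c4cc(F)c5c(c4C)CCCO5)n3n2)ccc1F` — > 40000 nM
compound 3 `CNC(=O)c1cc(F)ccc1CNC(=O)c1cc2nc(C)c([C@H](OC(C)(C)C)C(=O)O)c(-c3cc(F)c4c(c3C)CCCO4)n2n1` — > 40000 nM

In an ADME assay on MT2 cells (Homo sapiens) for cytotoxicity (a lower number here means that less compound is tolerated, a higher number that more compound is tolerated), compound 1 reaches only a limit of the assay at > 40000 nM. Compound 2 likewise shows only a limit in this assay, > 40000 nM. Compound 3 too gives only a limit, > 40000 nM. Compound 2 therefore stands at the same limit as the other two, and none of the three can be placed above or below the others; this is the limit of > 40000 nM in this assay, at which 3 of the 3 values shown sit.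

The piece follows the step to compound 4 `Cc1nc2cc(C(=O)NCC3CCCCC3)nn2c(-c2cc(F)c3c(c2C)CCCO3)c1[C@H](OC(C)(C)C)C(=O)O`, which is yet to be measured in this assay. The change is cyclohexyl in place of 3-ethyl-4-fluorophenyl on a saturated chain carbon bound to an amide-type nitrogen.

Of the measured steps, the one that touches the same place is a step that the two limits leave unreadable from compound 2 to compound 3; the steps a step that the two limits leave unreadable from compound 1 to compound 2 and a step that the two limits leave unreadable from compound 1 to compound 3 are equally unreadable. Every measured change at the amide-bearing end of the core has left the value at the limit, so he expects the step of a number no higher from compound 2 to compound 4 (the limit leaves the size open) to be none beyond the scatter and most likely a limit again. His estimate for compound 4 in this assay is 40000 nM, between 20000 nM and 80000 nM.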

Compound 4, half-maximal cytotoxic concentration: > 40000 nM
Compound 4 gave a limit, no number; the forecaster's own chance of this, stated with the estimate: 85%; the middle value lies on the limit itself.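

In this assay compound 4 gives > 40000 nM as a limit of the assay and not a number, so its steps from compound 1, compound 2 and compound 3 cannot be read. All four compounds stand at the same point: the limit of > 40000 nM in this assay, at which 4 of the 4 values shown sit. The compounds shown leave open whether any amide variant differs from another in cytotoxicity.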